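The source may report more compounds than this note shows. Statements on the series, on what has been measured and on what is new or still open speak of the compounds shown alone.

Compound 3 `NCC(=O)NCc1cccnc1Oc1ccc(F)cc1F` was tested in an assay on isolated protein for inhibition of protein arginine N-methyltransferase 6 (Homo sapiens) (a lower number here means a stronger inhibitor, a higher number a weaker inhibitor), and gave the result "not active" (no number reported), so no number stands for it and it is only known to be weak. Its neighbour compound 1 `C[C@H](N)C(=O)NCc1cccnc1Oc1ccc(F)cc1F`, which shares the core, gives 14000 nM in this assay, while the small fragment compound 2 `CNCCN1CCCC1` gives 1900 nM. Compound 4 `CN[C@@H](C)C(=O)NCc1cccnc1Oc1ccc(F)cc1F` differs from compound 3 by 1-(methylamino)ethyl in place of aminomethyl on a carbonyl carbon. Compound 4 is thus also the direct relative of compound 1, carrying one extra methyl on the amine. Among the compounds with values here, since compound 3 has no number, no step can be sized; on the strength of compound 1 at 14000 nM a modest gain toward stronger inhibition is expected, though it may not exceed the scatter. The estimate for compound 4 in this assay is 8000 nM, between 2000 nM and 40000 nM.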

Compound 4, half-maximal inhibitory concentration: "not active" (no number reported)
Compound 4 has no reported number here; there is nothing to compare the estimate with.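

Compound 3 and compound 4 are both reported as "not active" without a number, and no step can be read between them. No measurement shown bears on this result. The compounds shown leave open whether 1-(methylamino)ethyl in place of aminomethyl changes inhibition at all.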